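Compound 3: methyl in place of dimethylamino

A few compounds are considered here, and "the series" means these few. Any claim that something is new, unique, unknown or untested is made for them only; others in the source may bear on it.

Measured values from an ADME assay on HEp-2 cells (Homo sapiens) for cytotoxicity (a lower number here means that less compound is tolerated, a higher number that more compound is tolerated), follow
- compound 1 (`CC(C)CCn1c(Cn2c(=O)n(C(C)C)c3ccccc32)nc2cc(CN(C)C)ccc21`) gives 5650 nM
- compound 2 (`CC(C)CCn1c(Cn2c(=O)n(C(C)C)c3ccccc32)nc2ccc(C(N)=O)cc21`) gives 49900 nM

Compound 1 holds the lower number of the pair, and compound 2 stands higher, beyond the scatter. Compound 3 (`CCc1ccc2c(c1)nc(Cn1c(=O)n(C(C)C)c3ccccc31)n2CCC(C)C`) carries methyl in place of dimethylamino on a saturated chain carbon bound to an aromatic carbon. Among the measured compounds shown here, no measured step covers this change, so the expectation is tentative. In this assay the expected step of a 2.8-fold higher number from compound 1 to compound 3 (0.45 log units; beyond the scatter) goes upward, to a higher number. Compound 3 is estimated at 16000 nM with 6000 nM to 50000 nM as the expected range.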

Compound 3, half-maximal cytotoxic concentration: 18500 nM
Compound 3: middle estimate off by 1.2-fold (0.06 log units), on the low side, within the range that was stated.
By their numbers in this assay, from the lowest: compound 1; then compound 3; then compound 2.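

In this assay, among the compounds shown here, the exchange of dimethylamino for methyl on a saturated chain carbon bound to an aromatic carbon gives a 3.3-fold higher number from compound 1 to compound 3 (0.52 log units; beyond the scatter) and is the first single-place comparison at this position. It shows that, between these two compounds, the one carrying the (dimethylamino)methyl group is tolerated at the lower concentration, and that the ethyl group of compound 3 is tolerated at the higher. No measured property available here accounts for this step. On these data alone, whether the nitrogen or the size of the group matters remains open, and a primary amine, a methoxy group or a carboxylic acid on that carbon could separate the two.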